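Three Inactive Analogues and a Bromophenyl Question

A few compounds are considered here, and "the series" means these few. Any claim that something is new, unique, unknown or untested is made for them only; others in the source may bear on it.

Compound 1, `COc1cc(-c2nnc(SCC(=O)c3ccccc3)n2N)cc(OC)c1OC`: in a functional assay on PC-3 cells (Homo sapiens) for antiproliferative activity, read by MTT assay, with a stated time of 48 h (a higher number here means a weaker inhibitor, a lower number a stronger inhibitor), compound 1 gives > 100000 nM, a limit of the assay.
Compound 2, `COc1cc(-c2nnc(SCC(=O)c3ccc(Cl)cc3)n2N)cc(OC)c1OC`: compound 2 gives > 100000 nM, again a limit.
Compound 3, `COc1cc(-c2nnc(SCC(=O)c3ccc(C(F)(F)F)cc3)n2N)cc(OC)c1OC`: compound 3 gives > 100000 nM, also a limit.

Compound 3 therefore stands at the limit, and it does not stand alone there, because of the limit of > 100000 nM in this assay, at which 3 of the 3 values shown sit. None of the three steps between the measured compounds can be sized: a step that the two limits leave unreadable from compound 1 to compound 2, a step that the two limits leave unreadable from compound 1 to compound 3 and a step that the two limits leave unreadable from compound 2 to compound 3 are all hidden by the limit.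

Compound 4, `COc1cc(-c2nnc(SCC(=O)c3cccc(Br)c3)n2N)cc(OC)c1OC`, has not yet been measured. It differs from compound 3 in one place: 3-bromophenyl in place of 4-(trifluoromethyl)phenyl on a carbonyl carbon. Among the measured compounds shown here, the measured steps that bear on this change are the three just named, and all of them are unreadable, so they give no direction and no size for the step to compound 4. On this basis no step beyond the scatter is expected in this assay; the step from compound 3 to compound 4 is estimated as a step that the limit leaves unreadable from compound 3 to compound 4. Compound 4 is expected to give 150000 nM, with a range from 60000 nM to 400000 nM, and most likely to be reported only as a limit.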

Compound 4, half-maximal inhibitory concentration: > 100000 nM
Compound 4: no number, only a limit; the forecaster's own chance of this, stated with the estimate: 85%; the middle value is on the limit's open side.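

In this assay compound 4 gives > 100000 nM, a limit of the assay and not a number. No step between compound 4 and compound 1, compound 2 or compound 3 can be read, because all of them sit at the same limit: the limit of > 100000 nM in this assay, at which 4 of the 4 values shown sit.

The compounds shown leave open what structural change, if any, would give a measurable value in this assay.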